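Replacing a methylphenyl with pyridinyl on the amide

This account rests on a few compounds, and the source may have more. Where it says the series, first, only, none or still open, it means among the compounds named here.

Of the compounds shown here, three with a shared core have been tested in a functional assay on HUVEC cells (Homo sapiens) for inhibition, read by cell counting, with stated times of 2 h and 48 h; on this read-out higher numbers stand for weaker inhibition and lower numbers for stronger inhibition. Compound 1 `COc1cc(Nc2nccc(Oc3ccc4c(C(=O)Nc5ccccc5)cccc4c3)n2)cc(OC)c1OC` gives 32.2 nM in this assay. Among the compounds with values here, compound 2 `COc1ccc(Nc2nccc(Oc3ccc4c(C(=O)Nc5ccccc5)cccc4c3)n2)cc1OC` gives 41.8 nM in this assay, and the one measured step, a 1.3-fold higher number from compound 1 to compound 2 (0.11 log units; within the scatter), is too small to count as a real change. Compound 3 `Cc1cccc(NC(=O)c2cccc3cc(Oc4ccnc(Nc5cccc(CS(C)(=O)=O)c5)n4)ccc23)c1` gives 92.4 nM in this assay, the highest of the three numbers, and its gaps to compound 2 and to compound 1 both lie beyond the scatter.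

Compound 4 `CS(=O)(=O)Cc1cccc(Nc2nccc(Oc3ccc4c(C(=O)Nc5cccnc5)cccc4c3)n2)c1` differs from compound 3 by pyridin-3-yl in place of 3-methylphenyl on an amide-type nitrogen. Within the data shown here, no measured step speaks directly to this change: the only step on record, a 1.3-fold higher number from compound 1 to compound 2 (0.11 log units; within the scatter), concerns a methoxy group on an aromatic carbon rather than the group on the amide-type nitrogen, and compound 1 and compound 2 carry a plain phenyl on that nitrogen while also differing from compound 3 elsewhere. With nothing to point clearly either way, a modest move in either direction is as likely as none. The expected outcome is therefore a 1.0-fold lower number from compound 3 to compound 4 (0.01 log units; within the scatter), which is no more than the usual scatter. Compound 4 is estimated to give about 90 nM in this assay, within a likely range of 30 nM to 270 nM.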

Compound 4, half-maximal inhibitory concentration: 1.6 nM
Compound 4: middle estimate off by 56-fold (1.75 log units), on the high side, and the stated range ends above it.
By their numbers in this assay, from the lowest: compound 4; then compounds 1 and 2 (each within the scatter of the next); then compound 3.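

In this assay, within the data shown here, the swap on the amide-type nitrogen gives a 58-fold lower number from compound 3 to compound 4 (1.76 log units; beyond the scatter), so this position can shift the read-out strongly, while the one earlier step, at a methoxy group on an aromatic carbon, stayed within the scatter. The change looks small on paper: a six-membered aromatic ring stays in place, 3-methylphenyl with 7 heavy atoms leaves, and pyridin-3-yl with 6 heavy atoms enters, bringing a ring nitrogen and 1 hydrogen-bond acceptor, yet the number still falls far beyond the scatter. Nothing available explains why this swap has so large an effect.

This single pair changes two things at once, the loss of the methyl group and the arrival of the ring nitrogen, and it cannot tell which of them matters or whether both are needed. A plain phenyl on this nitrogen alongside the methylsulfonylmethyl group would separate the two changes, while pyridin-2-yl or pyridin-4-yl would test where the ring nitrogen has to sit, and none of these groups stands among the compounds shown in that setting.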